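The compounds below may be only part of what the source reports. "The series", "measured", "known", "first", "only" and "open" are said of these compounds alone.

In a functional assay on HepG2 cells (Homo sapiens) for inhibition, read by MTT assay, with a stated time of 72 h, tested at 30 uM (a higher number here means more inhibition of growth at the concentration tested, a lower number less inhibition of growth), compound 1 `C=CCc1ccc(OCc2cn(-c3ccccc3Cl)nn2)c(O)c1` gives 2.5%. This value lies within the scatter of compound 2 `C=CCc1cc(O)c(O)c(CN2CCC(CO)CC2)c1` at 4.7%, and both lie far from compound 3 `C=CCc1cc(O)c(O)c(CN2CCC(Cc3ccccc3)CC2)c1` at 70.2%. Compound 4 `C=CCc1ccc(OCc2cn(-c3ccc(Br)cc3)nn2)c(O)c1` has not yet been measured. It keeps the core of compound 1 and differs in one place: 4-bromophenyl in place of 2-chlorophenyl on an aromatic nitrogen. In words, it carries 4-bromophenyl in place of 2-chlorophenyl on an aromatic nitrogen. Among the measured compounds shown here, the only measured step between compounds differing in one place, a number 65.5 percentage points higher from compound 2 to compound 3 (beyond the scatter), is large. However, that step puts phenyl in place of hydroxy on a saturated chain carbon, on a different core, so it bears only weakly on this swap between two halogen-bearing phenyl groups. For the measured compounds named here, no measured step changes this group directly, so the evidence is thin. No step beyond the scatter is expected in this assay, although a modest rise remains possible. The estimated change is a number 5.5 percentage points higher from compound 1 to compound 4 (within the scatter). For compound 4, the estimated value is 8%, with an expected range of 0% to 30%.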

Compound 4, percent growth inhibition at one concentration: 8.9%
For compound 4 the middle estimate is 0.9 percentage points below the measured one; the measured number falls inside the stated range.
By their numbers in this assay, from the lowest: compounds 1, 2 and 4 (each within the scatter of the next); then compound 3.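

Among the compounds shown here, on the aromatic nitrogen of the five-membered ring, this is the first direct reading of a change of group: in this assay, 4-bromophenyl in place of 2-chlorophenyl gives a number 6.4 percentage points higher from compound 1 to compound 4 (within the scatter). The swap alters both the halogen and its place on the phenyl group, yet the two compounds stay within the scatter of each other, so this exchange between two halogen-bearing phenyl groups does not separate them in this assay. No measurement of any property of these groups accompanies the result, so it offers no explanation.

Still open, as far as these compounds go, is whether a different kind of group on that nitrogen, such as a phenyl bearing a carboxylic acid or an amine, or a longer chain, would give a step beyond the scatter. The effects of the halogen and its place also remain unseparated, and 4-chlorophenyl would be the group to tell them apart.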